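The source may hold more compounds than are shown below. What is called first, only, known or untested is meant among the compounds shown, and "the series" means these compounds.

In a functional assay on HepG2 cells (Homo sapiens) for antiproliferative activity, read by MTT assay, with a stated time of 24 h (a lower number here means a stronger inhibitor, a higher number a weaker inhibitor), compound 1 `O=c1[nH]cc(S(=O)(=O)Nc2ccc(-c3cn(-c4ccccc4)nn3)cc2)c(=O)[nH]1` gives 18000 nM and compound 3 `Cc1ccc(-n2cc(-c3ccc(NS(=O)(=O)c4c[nH]c(=O)[nH]c4=O)cc3)nn2)cc1` gives 11600 nM. These two values lie within the scatter of each other, the gap being a 1.6-fold lower number from compound 1 to compound 3 (0.19 log units; within the scatter). Compound 2 `Cc1cccc(-n2cc(-c3ccc(NS(=O)(=O)c4c[nH]c(=O)[nH]c4=O)cc3)nn2)c1` gives > 20000 nM, which is a limit of the assay and not a number.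

Compound 4 `O=c1[nH]cc(S(=O)(=O)Nc2ccc(-c3cn(-c4cccc(F)c4)nn3)cc2)c(=O)[nH]1` differs from compound 3 by 3-fluorophenyl in place of 4-methylphenyl on an aromatic nitrogen. Going by the values given here, no measured compound carries fluorine, so the nearest guides are the methyl steps on the same aryl group. Besides the gap above, these are an at least 1.1-fold higher number from compound 1 to compound 2 (0.04 log units; that floor lies within the scatter) and an at least 1.7-fold lower number from compound 2 to compound 3 (0.23 log units; that floor lies within the scatter). The last two are floors only. The 3-methylphenyl group of compound 2 is the closest match by name to the entering group, which leaves some room for a drift towards higher numbers. In this assay the expected step is a 1.3-fold higher number from compound 3 to compound 4 (0.11 log units; within the scatter), with nothing expected beyond the scatter. The estimate for compound 4 is 15000 nM, with an expected range of 7000 nM to 30000 nM.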

Compound 4, half-maximal inhibitory concentration: > 20000 nM
Compound 4 gave a limit, no number (the forecaster's own chance of this, stated with the estimate: 25%); middle value at least 1.3-fold (0.12 log units) from the limit.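

In this assay compound 4 gives > 20000 nM, which is a limit of the assay and not a number. With 3-fluorophenyl on the aromatic nitrogen, the series now holds a second 3-substituted phenyl group that returns no number, but an at least 1.7-fold higher number from compound 3 to compound 4 (0.23 log units; that floor lies within the scatter) and an at least 1.1-fold higher number from compound 1 to compound 4 (0.04 log units; that floor lies within the scatter) are floors within the scatter, so neither establishes a real loss. The step between compound 2 and compound 4 cannot be read, and the floors stay small because the measurable range ends at the value shared by these two compounds: the limit of > 20000 nM in this assay, at which 2 of the 4 values shown sit.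

Going by these compounds, how far compound 2 and compound 4 lie beyond the limit remains open. Also open, on these data alone, is whether 4-fluorophenyl, 4-methoxyphenyl or 3-aminophenyl on the same nitrogen would give a number, and thus whether the place of the group on the phenyl ring matters at all.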